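Taking the Methyl Off Compound 3

The source may hold more compounds than are shown below. What is called first, only, known or untested is meant among the compounds shown, and "the series" means these compounds.

Compound 3 `Cc1ccccc1NC(=O)/C=C/c1coc2cc(O)ccc2c1=O` is one of two compounds in this small set whose result is only a limit: in a functional assay on A549 cells (Homo sapiens) for inhibition, read by MTT assay, with a stated time of 48 h (on this read-out lower numbers stand for stronger inhibition and higher numbers for weaker inhibition), compound 3 gives > 100000 nM, a limit and not a number. Compound 1 `O=C(/C=C/c1coc2cc(O)ccc2c1=O)NCc1ccccc1` likewise reaches only the limit > 100000 nM in this assay. Compound 2 `COc1ccc(NC(=O)/C=C/c2coc3cc(O)ccc3c2=O)cc1` gives 12800 nM in this assay. Compound 4 `O=C(/C=C/c1coc2cc(O)ccc2c1=O)Nc1ccccc1` differs from compound 3 by hydrogen in place of methyl on an aromatic carbon. The step of an at least 7.8-fold higher number from compound 2 to compound 3 (0.89 log units; beyond the scatter) shows that exchanging the 4-methoxyphenyl for the 2-methylphenyl costs activity, while a step that the two limits leave unreadable from compound 1 to compound 3 cannot be read. Compound 4 stands between these two amides, so a modest drop in number, an at least 1.6-fold lower number from compound 3 to compound 4 (0.22 log units; that floor lies within the scatter), is expected, though a limit again is quite possible. Compound 4 is expected at 60000 nM, within 10000 nM to 200000 nM.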

Compound 4, half-maximal inhibitory concentration: 24400 nM
Estimate against measurement, compound 4: 2.5-fold (0.39 log units) above; the measured number falls inside the stated range.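

Taking off the methyl gives an at least 4.0-fold lower number from compound 3 to compound 4 (0.61 log units; beyond the scatter), so in this assay a methyl at this place, ortho to a large group, goes with weaker inhibition. Phenyl in place of benzyl on the amide nitrogen gives an at least 4.0-fold lower number from compound 1 to compound 4 (0.61 log units; beyond the scatter), while hydrogen in place of methoxy gives a 1.9-fold higher number from compound 2 to compound 4 (0.28 log units; within the scatter), so the 4-methoxyphenyl and phenyl amides cannot be told apart here. The two steps starting from a limit are floors, not exact sizes: the limit of > 100000 nM in this assay, at which 2 of the 4 values shown sit.

On these data alone, whether a chlorine or a hydroxyl on this same carbon would also weaken inhibition remains open. So does whether an ethyl there would weaken it further than methyl.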